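Methoxy to Methyl on the Ring: Expected Toxicity

The compounds below may be only part of what the source reports. "The series", "measured", "known", "first", "only" and "open" are said of these compounds alone.

Compound 1, `C#CCNC(=O)/C(C)=C(\C)c1ccc(OC)cc1`: 400 mg/kg
Compound 2, `C=CCNC(=O)/C(C)=C(\C)c1ccc(OC)cc1`: 300 mg/kg
Compound 3, `C#CCNC(=O)/C(C)=C(\C)c1cc(OC)c(OC)c(OC)c1`: 300 mg/kg

In a toxicity assay on the whole organism (strain Icem-CET (SPF Caw)) for cytotoxicity, with Mus musculus as the target (on this read-out lower numbers stand for an effect already at smaller amounts and higher numbers for an effect only at larger amounts of compound), compound 2 gives 300 mg/kg. Among the compounds with values here, that number matches the one for compound 3 to the digits given, and compound 1 lies only within the usual scatter of it, so the three measured compounds are not separated by this assay. Within the data shown here, the one step between measured compounds that differ in a single place is a 1.3-fold lower number from compound 1 to compound 2 (0.12 log units; within the scatter); it changes the chain on the amide nitrogen and left the number essentially where it was.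

Compound 4, `C=CCNC(=O)/C(C)=C(\C)c1ccc(C)cc1`, differs from compound 2 by methyl in place of methoxy on an aromatic carbon. Among the measured compounds shown here, no measured step concerns this part of the molecule, so there is nothing that points to a shift in either direction. The expectation is therefore a step of no change at the digits printed from compound 2 to compound 4 (within the scatter), no more than the scatter. Compound 4 is estimated to give 300 mg/kg in this assay, with a range from 150 mg/kg to 600 mg/kg.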

Compound 4, dose for half-maximal effect: 170 mg/kg
Compound 4: middle estimate off by 1.8-fold (0.25 log units), on the high side; measured number inside the range.
By their numbers in this assay, from the lowest: compounds 4, 2, 3 and 1 (each within the scatter of the next, the first and the last beyond it).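

Putting methyl in place of methoxy on this aromatic carbon gives a 1.8-fold lower number from compound 2 to compound 4 (0.25 log units; within the scatter) in this assay and so does not clearly separate the two compounds. Within the data shown here, this is the first single-place step on the ring, para to a large group, whereas the earlier step concerned the chain on the amide nitrogen. It shows that replacing methoxy, which counts one hydrogen-bond acceptor, with methyl, which counts none, gives a difference that repeated measurements could produce on their own, and no supporting data bear on this result.

Going by these compounds, whether an amine or a carboxylic acid on this same carbon would give a step beyond the scatter remains open. On these data alone, it is also open whether methyl in place of methoxy gives a similar step when the chain on the amide nitrogen carries ethynyl instead of vinyl.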